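Compound 1 to compound 4: adding bromo

The source may hold more compounds than are shown below. What is called first, only, known or untested is meant among the compounds shown, and "the series" means these compounds.

Going by the values given here, in an ADME assay on HaCaT cells (Homo sapiens) for inhibition, read by spectrophotometry and sulforhodamine B assay, with a stated time of 48 h (a lower number here means a stronger inhibitor of growth, a higher number a weaker inhibitor of growth), compound 1 `O=C1CS/C(=N/N=C/c2c[nH]c3ccccc23)N1c1cccc2ccccc12` gives 63000 nM, the highest of the three numbers so far and therefore the weakest inhibitor of growth in the set. The nearest value belongs to compound 2 `S=C(N/N=C/c1c[nH]c2ccc(Br)cc12)Nc1cccc2ccccc12`, at 6150 nM. The furthest belongs to compound 3 `Cc1ccc(NC(=S)N/N=C/c2c[nH]c3ccccc23)cc1`, at 990 nM. Both gaps from compound 1 lie beyond the scatter.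

Compound 4 `O=C1CS/C(=N/N=C/c2c[nH]c3ccc(Br)cc23)N1c1cccc2ccccc12` keeps the core of compound 1 and makes a single change: bromo in place of hydrogen on an aromatic carbon. The change is bromo in place of hydrogen on an aromatic carbon of a six-membered aromatic ring of carbon only, part of a fused or bridged system of two rings.

Among the compounds with values here, no measured pair isolates this change. Compound 2 carries the same bromo and gives 6150 nM, but it also differs from compound 1 elsewhere, so its value offers only weak support. With this limited evidence, a modest move towards a lower number in this assay is expected, although a result within the scatter would not be surprising.

The expected size of the change is a 2.1-fold lower number from compound 1 to compound 4 (0.32 log units; beyond the scatter).

For compound 4, the estimated value is 30000 nM, with an expected range of 9000 nM to 90000 nM.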

Compound 4, concentration for 50% growth inhibition: 6230 nM
Compound 4: middle estimate off by 4.8-fold (0.68 log units), on the high side, and the stated range ends above it.
By their numbers in this assay, from the lowest: compound 3; then compounds 2 and 4 (each within the scatter of the next); then compound 1.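

In this assay, going by these compounds alone, bromo in place of hydrogen on an aromatic carbon, meta to a fused ring and para to a fused ring, gives a 10-fold lower number from compound 1 to compound 4 (1.00 log units; beyond the scatter) and is the first single change that can be read directly. Compound 2 carries the same bromo but also differs elsewhere from compound 1, so the earlier values could not separate the contribution of this substitution from that of the other difference; this pair now shows that, on the core of compound 1, the substitution alone is enough to produce a step of this size. Nothing measured here accounts for that size.

On these data alone, the pair covers a single group at a single place, so whether chloro, methoxy or an amine on the same aromatic carbon would move the number as far remains open. Compound 2 also has no partner lacking the bromo among the compounds shown, which leaves open whether the same change produces a comparable step on that different core.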